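This account rests on a few compounds, and the source may have more. Where it says the series, first, only, none or still open, it means among the compounds named here.

Measured compounds:
compound 1 `CCN(CC)S(=O)(=O)c1ccc(S(=O)(=O)N2CCC[C@@H](C(=O)NC3COC3)C2)cc1` — 2300 nM
compound 2 `CCN(CC)C(=O)c1ccc(S(=O)(=O)N2CCC[C@@H](C(=O)N3CCN(c4nc(C(C)C)no4)CC3)C2)cc1` — 100 nM

In a functional assay on MIA PaCa-2 cells (Homo sapiens) for inhibition, read by MTT assay, with a stated time of 7 days (a higher number here means a weaker inhibitor, a lower number a stronger inhibitor), compound 2 gives 100 nM, the lowest of the two numbers recorded. For the measured compounds named here, compound 1 gives 2300 nM in this assay, a number well beyond the scatter above that of compound 2; the two compounds differ in more than one place, so the comparison shows only that compound 2 is the stronger inhibitor of the pair.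

Compound 3 `CC(C)c1noc(N2CCN(C(=O)[C@@H]3CCCN(S(=O)(=O)c4ccc(S(=O)(=O)NC5CCC5)cc4)C3)CC2)n1` has not yet been measured. It keeps the core of compound 2 and changes one substituent: cyclobutylsulfamoyl in place of diethylcarbamoyl on an aromatic carbon. Going by the values given here, no measured pair isolates this change, so the expectation rests on the single value of compound 2.

Compound 3 is expected to be a somewhat weaker inhibitor, with a step from compound 2 of a 2.5-fold higher number from compound 2 to compound 3 (0.40 log units; beyond the scatter), a little beyond the scatter. In this assay compound 3 is estimated at 250 nM, within a range from 80 nM to 800 nM.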

Compound 3, half-maximal inhibitory concentration: 600 nM
Beside the measured number, compound 3's estimate is 2.4-fold (0.38 log units) below it; the range from low to high includes it.
By their numbers in this assay, from the lowest: compound 2; then compound 3; then compound 1.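

In this assay, placing cyclobutylsulfamoyl in place of diethylcarbamoyl on an aromatic carbon, para to a large group, gives a 6.0-fold higher number from compound 2 to compound 3 (0.78 log units; beyond the scatter). This is the first change shown on its own with the rest of the molecule held fixed, since compound 1 and compound 2 differ in more than one place, and it shows that inhibition in these cells responds to what stands at this position. Nothing available explains the weaker inhibition of compound 3.

The compounds shown leave open whether the step follows the change from carbamoyl to sulfamoyl or the change from the diethyl groups to the cyclobutyl ring, a question that cyclobutylcarbamoyl at this position would address. From the compounds shown here alone, it also remains open how this position would respond to a carboxylic acid or an amine.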